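The source may hold more compounds than are shown below. What is called first, only, known or untested is meant among the compounds shown, and "the series" means these compounds.

Compound 1 `Cc1cc(-c2cccc(F)c2)nnc1N1CCN(c2ncccn2)CC1` carries a 3-fluorophenyl group on the shared core, and in a functional assay on BV-2 cells (Mus musculus) for inhibition, read by ELISA, with a stated time of 16 h (a lower number here means a stronger inhibitor, a higher number a weaker inhibitor), compound 1 gives 33500 nM. Compound 2 `Cc1cc(-c2ccncc2)nnc1N1CCN(c2ncccn2)CC1` has pyridin-4-yl in that place. In this assay compound 2 reaches only a limit of the assay, > 100000 nM, which is a bound and not a number. The step of an at least 2.9-fold higher number from compound 1 to compound 2 (0.47 log units; beyond the scatter) is thus known only as a bound, since one of the two values shown sits at the limit of > 100000 nM in this assay, at which 1 of the 2 values shown sits. Compound 3 `Cc1cc(-c2cncnc2)nnc1N1CCN(c2ncccn2)CC1` has not yet been measured; it differs from compound 2 in one place: pyrimidin-5-yl in place of pyridin-4-yl on an aromatic carbon. Among the measured compounds shown here, only that single step from compound 1 to compound 2 bears on this change, and it ran toward a weaker inhibitor when pyridin-4-yl replaced 3-fluorophenyl. Adding a second hetero atom to that ring is expected to leave the number at or beyond the limit rather than lower it, so the step that the limit leaves unreadable from compound 2 to compound 3 is expected to be flat or toward a higher number. Compound 3 is therefore estimated at 150000 nM, within 60000 nM to 400000 nM, most likely reported again only as a limit.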

Compound 3, half-maximal inhibitory concentration: > 100000 nM
Compound 3: no number, only a limit; the forecaster's own chance of this, stated with the estimate: 75%; the middle value is on the limit's open side.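

Pyrimidin-5-yl on this aromatic carbon gives an at least 2.9-fold higher number from compound 1 to compound 3 (0.47 log units; beyond the scatter), so in this assay the weakening seen with pyridin-4-yl is not confined to that one ring: both nitrogen-containing rings shown here lie beyond the scatter from the 3-fluorophenyl group of compound 1. Of the three groups shown at this position, only 3-fluorophenyl gives a readable number, and neither nitrogen-containing ring does. The step between the two nitrogen-containing rings cannot be read, so nothing can be said about what the second ring nitrogen does, because both of their compounds sit at the top of the measurable range: the limit of > 100000 nM in this assay, at which 2 of the 3 values shown sit.

Going by these compounds, what stays open is whether the weakening follows from the ring nitrogens or from the loss of the fluorine, and a plain phenyl group on this carbon would separate the two, depending on whether it sat with compound 1 or at the limit. Also open, on these data alone, is whether any group here, such as 3-chlorophenyl or 3-methoxyphenyl, would give a lower number than compound 1 does.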